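Oleoyl ketone series: pyridin-2-yl to pyridazin-3-yl on the carbonyl

This account rests on a few compounds, and the source may have more. Where it says the series, first, only, none or still open, it means among the compounds named here.

Compound 1 `CCCCCCCC/C=C\CCCCCCC(=O)c1ccccn1` is the starting point. In an assay on isolated protein for inhibition of Fatty-acid amide hydrolase 1 (Homo sapiens) (a higher number here means a weaker inhibitor, a lower number a stronger inhibitor), compound 1 gives > 100000 nM, which is a limit of the assay and not a number. For the measured compounds named here, the only other measurement comes from compound 2 `O=C(O)c1cccc(CCCCCCC(=O)c2ncc(-c3ccccn3)o2)c1`, built on a different scaffold. In this assay compound 2 gives > 600 nM, again a limit rather than a number. Going by the values given here, both values therefore sit at limits, the limit of > 100000 nM in this assay, at which 1 of the 2 values shown sits, and (the limit of > 600 nM in this assay, at which 1 of the 2 values shown sits), and no step between measured compounds can be read.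

The unmeasured compound 3 `CCCCCCCC/C=C\CCCCCCC(=O)c1cccnn1` carries the change (pyridazin-3-yl in place of pyridin-2-yl on a carbonyl carbon), keeping the rest of compound 1. Among the compounds with values here, with compound 1 standing at a limit, no direction for the step is supported by measured pairs; some movement in either direction beyond the scatter cannot be excluded. Compound 3 is expected at 50000 nM in this assay, with a range from 5000 nM to 200000 nM, which means an estimated step of an at least 2.0-fold lower number from compound 1 to compound 3 (0.30 log units; that floor lies within the scatter).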

Compound 3, inhibition constant: 130 nM
Estimate against measurement, compound 3: 380-fold (2.59 log units) above; the whole stated range lies above it.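

In this assay, the group on the carbonyl carbon of the oleoyl ketone proves a sensitive point: with the chain unchanged, pyridazin-3-yl in place of pyridin-2-yl gives an at least 760-fold lower number from compound 1 to compound 3 (2.88 log units; beyond the scatter). For the compounds shown here, this is the first step that can be read, and it shows that exchanging one six-membered aromatic ring for another with 2 hetero atoms can take an unchanged chain from a limit to a measured value. Compound 1 stands at a limit and not a number, so the step is only a floor and its full size stays unknown: the limit of > 100000 nM in this assay, at which 1 of the 3 values shown sits.

On these data alone, it remains open whether pyrimidin-2-yl or pyrazin-2-yl on the carbonyl would give a similar step. Also open, as far as these compounds go, is whether pyridazin-3-yl keeps this effect with a shorter saturated chain or an amine at the chain end.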